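Triazole series: amide cap change from compound 1 to compound 4

The source may report more compounds than this note shows. Statements on the series, on what has been measured and on what is new or still open speak of the compounds shown alone.

Measured compounds in a functional assay on CHO cells for antagonist activity at growth hormone secretagogue receptor type 1 (Homo sapiens); a lower number here means a stronger inhibitor, a higher number a weaker inhibitor:
- compound 1 `COc1ccc(Cn2c(CCc3c[nH]c4ccccc34)nnc2[C@H](NC(=O)C(C)(C)N)c2c[nH]c3ccccc23)c(OC)c1`: 14 nM
- compound 2 `COc1ccc(Cn2c(CCc3ccccc3)nnc2[C@H](NC(=O)C(C)(C)N)c2c[nH]c3ccccc23)cc1`: 5 nM
- compound 3 `COc1ccc(Cn2c(CCc3ccccc3)nnc2[C@H](NC(=O)C(C)(C)N)c2c[nH]c3ccccc23)c(OC)c1`: 17 nM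

Compound 1 sits second highest of the three numbers in this assay. Its nearest neighbour is compound 3, reached by a 1.2-fold higher number from compound 1 to compound 3 (0.08 log units; within the scatter), a step that stays within the scatter. Its furthest neighbour is compound 2, whose number is lower; the step of a 3.4-fold higher number from compound 2 to compound 3 (0.53 log units; beyond the scatter) shows that the extra methoxy on the aromatic carbon costs a modest amount.

Compound 4 `COc1ccc(Cn2c(CCc3c[nH]c4ccccc34)nnc2[C@H](NC(=O)c2ccccn2)c2c[nH]c3ccccc23)c(OC)c1` is not yet measured. It differs from compound 1 at the amide cap: pyridin-2-yl in place of 1-amino-1-methylethyl on a carbonyl carbon. Neither measured step touches the carbonyl carbon or the group on it; both concern the saturated chain or the aromatic ring carrying the methoxy groups. There is therefore no direct guide for this change within the series, and the expectation rests only on the shared core and the size of the exchange. The loss of the donor-bearing group and entry of an aromatic ring is expected to move the number upward by a modest step, a 2.9-fold higher number from compound 1 to compound 4 (0.46 log units; beyond the scatter), with wide uncertainty. Compound 4 is therefore estimated at 40 nM in this assay, with a range from 8 nM to 250 nM.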

Compound 4, antagonist equilibrium constant: 19 nM
For compound 4 the middle estimate is 2.1-fold (0.32 log units) above the measured one; measured number inside the range.
By their numbers in this assay, from the lowest: compound 2; then compounds 1, 3 and 4 (each within the scatter of the next).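

At the carbonyl carbon, pyridin-2-yl in place of 1-amino-1-methylethyl gives a 1.4-fold higher number from compound 1 to compound 4 (0.13 log units; within the scatter) in this assay and so stays within the scatter, even though the exchange replaces an open group with one six-membered aromatic ring. This is the only step shown at this position, and it shows that on the core of compound 1 the number in this assay does not depend on keeping the 1-amino-1-methylethyl cap or its 1 hydrogen-bond donor, since pyridin-2-yl has 0 hydrogen-bond donors. No measurement on hand bears on why the two caps read alike.

The compounds shown leave open whether the ring nitrogen of pyridin-2-yl counts at all, which phenyl on the same carbonyl carbon would test, and how a carboxylic acid or a longer amine-bearing chain there would read. Also open, going by these compounds, is whether the same cap exchange holds on the cores of compound 2 and compound 3, where the methoxy pattern or the phenyl chain differs from compound 1.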